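The source may report more compounds than this note shows. Statements on the series, on what has been measured and on what is new or still open speak of the compounds shown alone.

Working notes on the series.

Three compounds in this set carry the same core, with the substituent on the ring nitrogen varied alongside the groups on the other positions: compound 1 `COc1ccc(Cn2c(-c3ccccc3)c(-c3ccccc3)c3c(=N)n(CCCO)cnc32)cc1`, compound 2 `COc1ccc(-c2c(-c3ccc(OC)cc3)n(Cc3ccccc3)c3ncn(CC4CCOC4)c(=N)c23)cc1` and compound 3 `N=c1c2c(-c3ccccc3)c(-c3ccccc3)n(CC3CC3)c2ncn1CC1CCOCC1`. In an ADME assay on microsomes from liver (Mus musculus, strain CD1) for metabolic stability, read by LC-MS, using NADPH, with a stated time of 60 min (on this read-out lower numbers stand for a shorter-lived compound and higher numbers for a longer-lived compound), compound 1 gives 0.332 h. In this assay compound 2 gives 0.275 h, and compound 3 gives 0.272 h. Compound 2 stands second of the three numbers, but its nearest neighbour is compound 3 and its furthest is compound 1, and both gaps lie within the scatter of repeated measurements, so no order among the three can be read from these values. Going by the values given here, no pair of measured compounds differs in a single place, so the set gives no measured step to lean on.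

The next compound is compound 4 `COc1ccc(-c2c(-c3ccc(OC)cc3)n(Cc3ccccc3)c3ncn(C4CCOCC4)c(=N)c23)cc1`. It differs from compound 2 in one place: oxan-4-yl in place of (oxolan-3-yl)methyl on an aromatic nitrogen. The two compounds have the same atoms, joined differently, and the change keeps the count of heavy atoms, donors and acceptors unchanged.

With no measured step of this kind in the set, the step of a 1.1-fold higher number from compound 2 to compound 4 (0.04 log units; within the scatter) is expected to stay within the scatter, in no particular direction. Compound 4 is therefore expected to give about 0.3 h in this assay, with a range from 0.15 h to 0.6 h.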

Compound 4, half-life: 0.978 h
For compound 4 the middle estimate is 3.3-fold (0.51 log units) below the measured one; measured number above the stated range.
By their numbers in this assay, from the lowest: compounds 3, 2 and 1 (each within the scatter of the next); then compound 4.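

In this assay, going by these compounds alone, the position on the aromatic nitrogen turns out not to be indifferent to how the same atoms are joined: oxan-4-yl in place of (oxolan-3-yl)methyl gives a 3.6-fold higher number from compound 2 to compound 4 (0.55 log units; beyond the scatter) and so provides the first measured step, one that lies beyond the scatter and points towards a longer half-life. The heavy atoms, donors and acceptors stay the same in number across this step, so those counts alone do not account for the change in half-life, and what differs between the two groups is the ring, six-membered against five-membered, and how it is attached. Nothing measured in this set bears on what lies behind the step.

The single step changes ring size and attachment together, so the compounds shown cannot separate the two; oxolan-3-yl on the same aromatic nitrogen would divide them, and a piperidin-4-yl group, an amine, would test whether the ring oxygen matters. Going by these compounds, whether the same step holds with the other groups of the core changed, such as phenyl in place of methoxyphenyl, also stays open.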